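Triazole Ureas: One Swap Repeated on a Longer Chain

This account rests on a few compounds, and the source may have more. Where it says the series, first, only, none or still open, it means among the compounds named here.

Three urea-linked compounds have been measured in an ADME assay on WI-38 cells (Homo sapiens) for cytotoxicity, read by MTT assay, with a stated time of 72 h; a lower number here means a stronger inhibitor, a higher number a weaker inhibitor. Compound 1 `CN(C)CCn1cnnc1-c1cc(Oc2ccc(NC(=O)Nc3ccc(F)c(Cl)c3)cc2F)ccn1` gives 7580 nM. Compound 2 `CN(C)CCn1cnnc1-c1cc(Oc2ccc(NC(=O)Nc3ccc(Cl)cc3Cl)cc2F)ccn1` gives 10400 nM in this assay, and compound 3 `CN(C)CCCn1cnnc1-c1cc(Oc2ccc(NC(=O)Nc3ccc(F)c(Cl)c3)cc2F)ccn1` gives 5370 nM. Compound 2 differs from compound 1 by a single change, (2,4-dichlorophenyl in place of 3-chloro-4-fluorophenyl on an amide-type nitrogen), and that change made a step of a 1.4-fold higher number from compound 1 to compound 2 (0.14 log units; within the scatter). Compound 3 differs from compound 1 only in its core, ((dimethylamino)methyl in place of dimethylamino on a saturated chain carbon, two bonds along the chain from an aromatic nitrogen), with a step of a 1.4-fold lower number from compound 1 to compound 3 (0.15 log units; within the scatter).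

Compound 4 `CN(C)CCCn1cnnc1-c1cc(Oc2ccc(NC(=O)Nc3ccc(Cl)cc3Cl)cc2F)ccn1` has not yet been measured. It shares the core of compound 3 and differs from it by 2,4-dichlorophenyl in place of 3-chloro-4-fluorophenyl on an amide-type nitrogen. The place of this change is described in exactly the same words as for the change from compound 1 to compound 2, so it is the same change made on the other core.

Among the compounds with values here, a step of about the same size is expected, a 1.4-fold higher number from compound 3 to compound 4 (0.14 log units; within the scatter), because the earlier step was a 1.4-fold higher number from compound 1 to compound 2 (0.14 log units; within the scatter), and that single example is the only guide available. For compound 4 the estimated value in this assay is 7400 nM, with most repeats expected to fall between 3700 nM and 15000 nM.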

Compound 4, half-maximal inhibitory concentration: 3260 nM
Estimate against measurement, compound 4: 2.3-fold (0.36 log units) above, outside the stated range (below it).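

In this assay, placing 2,4-dichlorophenyl where 3-chloro-4-fluorophenyl stood on the core of compound 3 gives a step of a 1.6-fold lower number from compound 3 to compound 4 (0.22 log units; within the scatter), and this can be set beside the same change on the core of compound 1: the same change on two cores in this assay, a 1.4-fold higher number (0.14 log units; within the scatter) from compound 1 to compound 2 and a 1.6-fold lower number (0.22 log units; within the scatter) from compound 3 to compound 4, 2.3-fold (0.35 log units) apart, within the scatter of two such steps. The other change, (dimethylamino)methyl in place of dimethylamino, gives a step of a 3.2-fold lower number from compound 2 to compound 4 (0.50 log units; beyond the scatter), the only step among these four compounds beyond the scatter, and it too has a partner: the same change on two cores in this assay, a 1.4-fold lower number (0.15 log units; within the scatter) from compound 1 to compound 3 and a 3.2-fold lower number (0.50 log units; beyond the scatter) from compound 2 to compound 4, 2.3-fold (0.35 log units) apart, within the scatter of two such steps. Both changes therefore carry from one core to the other within the scatter, but this rests on a single pair of steps for each change, so it neither shows that the steps are truly equal nor makes the opposite directions of the two aryl steps a real reversal.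

The compounds shown leave open whether this aryl change would behave alike with a longer chain or with morpholine in place of dimethylamino. They also leave open what a phenyl bearing trifluoromethyl would do on either core.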